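The source may hold more compounds than are shown below. What is called first, only, known or untested is meant among the compounds shown, and "the series" means these compounds.

The series consists of two measured compounds and one still to be measured, all sharing the same core. Compound 1 `C=C1CC[C@H]2[C@@](C)(CCC(=O)[C@@]2(C)COC(C)=O)[C@@H]1C/C=C1/C(=O)OC[C@@H]1Oc1c(Cl)cc(Cl)c2cccnc12` and compound 2 `C=C1CC[C@@H]2[C@](C)(CO)[C@H](O)CC[C@@]2(C)[C@@H]1C/C=C1/C(=O)OC[C@H]1Oc1c(Cl)cc(Cl)c2cccnc12` were both tested in a toxicity assay on SNB-19 cells (Homo sapiens) for cytotoxicity, with a stated time of 24 h; a lower number here means that less compound is tolerated, a higher number that more compound is tolerated. In this assay compound 1 gives 72000 nM. In this assay compound 2 gives 85200 nM. Compound 2 stands at the highest of the two numbers, but its nearest neighbour is compound 1 and the two values lie within the scatter of each other, so nothing can be said of an order between them. Among the measured compounds shown here, the two compounds differ in more than one place, so no single step joins them.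

Compound 3 `C=C1CC[C@@H]2[C@](C)(CO)[C@H](O)CC[C@@]2(C)[C@@H]1C/C=C1/C(=O)OC[C@H]1Oc1cccnc1[N+](=O)[O-]` differs from compound 2 in one place: 2-nitropyridin-3-yl in place of 5,7-dichloroquinolin-8-yl on an oxygen on a saturated carbon. For the measured compounds named here, no comparable step is known among the measured compounds, and the two measured numbers lie close together. On that basis the step of a 1.1-fold lower number from compound 2 to compound 3 (0.03 log units; within the scatter) is expected to stay within the scatter, with no clear direction. For compound 3 the estimate in this assay is 80000 nM, with a range from 35000 nM to 180000 nM.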

Compound 3, half-maximal cytotoxic concentration: 67700 nM
Estimate against measurement, compound 3: 1.2-fold (0.07 log units) above; the measured number falls inside the stated range.
By their numbers in this assay, from the lowest: compounds 3, 1 and 2 (each within the scatter of the next).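

Among the compounds shown here, the exchange of 5,7-dichloroquinolin-8-yl for 2-nitropyridin-3-yl on an oxygen on a saturated carbon is the first change that can be read on its own, and in this assay it gives a 1.3-fold lower number from compound 2 to compound 3 (0.10 log units; within the scatter), which lies within the scatter. At this position, a group with one aromatic ring, two nitrogen atoms and two oxygen atoms therefore takes the place of a group with two aromatic rings and two chlorine atoms with no distinguishable difference in the number. No measured information on these compounds explains this outcome.

On these data alone, it remains open whether the same tolerance holds for groups of another kind on this oxygen, such as an amine-bearing alkyl chain, a carboxylic acid or a longer alkyl chain, since both groups compared so far are attached through an aromatic ring. As far as these compounds go, it is also open whether the exchange would give the same result on the core of compound 1, which differs from compound 2 in more than one place.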